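The source may report more compounds than this note shows. Statements on the series, on what has been measured and on what is new or still open speak of the compounds shown alone.

In an ADME assay on J774 cells (Mus musculus) for cytotoxicity, read by MTT assay, with a stated time of 48 h, tested at 150 ug/mL (on this read-out higher numbers stand for a weaker effect at the one concentration tested and lower numbers for a stronger effect), compound 1, with structure `CCOc1ccc(/C=N/NC(=O)c2cnccn2)cc1`, gives 100%. Compound 2, with structure `O=C(N/N=C/c1ccc(O)cc1)c1cnccn1`, gives 80% in this assay. Among the measured compounds shown here, the one step between them, a number 20 percentage points lower from compound 1 to compound 2 (beyond the scatter), is the only measured step in the set. Compound 2 therefore stands lowest of the two numbers in this assay, with compound 1 the nearest and lying higher, beyond the scatter.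

Compound 3 has structure `CN(C)c1ccc(/C=N/NC(=O)c2cnccn2)cc1`. It differs from compound 2 by dimethylamino in place of hydroxy on an aromatic carbon, that is, a dimethylamino group in place of a hydroxy group on an aromatic carbon of a six-membered aromatic ring of carbon only, para to a large group. The step from compound 1 to compound 2 is the only one that bears on this change, and it concerns the same position of the shared core but a different pair of groups, so it is a loose guide at best. That step was modest; a step of similar modest size is therefore expected here, in the direction of a higher number, since compound 2 with 80% sits below compound 1 with 100%. The step from compound 2 to compound 3 in this assay is estimated at a number 12 percentage points higher from compound 2 to compound 3 (beyond the scatter). For compound 3 in this assay the expected value is 92%, with a range from 75% to 105%.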

Compound 3, a percentage reported as activity, at one concentration (the size of the read-out at that concentration, not a potency): 89%
Beside the measured number, compound 3's estimate is 3 percentage points above it, and the stated range covers the measured number.
By their numbers in this assay, from the lowest: compounds 2 and 3 (each within the scatter of the next); then compound 1.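

At this place, on an aromatic carbon of a six-membered aromatic ring of carbon only, para to a large group, dimethylamino in place of hydroxy gives a number 9 percentage points higher from compound 2 to compound 3 (within the scatter) in this assay, so compound 2 and compound 3 cannot be told apart on this read-out, although the entering group has no hydrogen-bond donor and has more heavy atoms. Dimethylamino in place of ethoxy gives a number 11 percentage points lower from compound 1 to compound 3 (beyond the scatter), which shows that hydroxy is not the only group at this place to give a lower number than ethoxy, and that a hydrogen-bond donor on this carbon is not needed for such a number.

The compounds shown carry only ethoxy, hydroxy and dimethylamino here, so it stays open how an unsubstituted amine, a carboxylic acid or a longer chain such as butoxy would read in this assay. Also open, going by these compounds, is whether the same swaps would give steps of similar size with another group in place of the pyrazine-free remainder of the shared core, or with chlorine at this place.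

No measured evidence accounts for these steps.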